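This account rests on a few compounds, and the source may have more. Where it says the series, first, only, none or still open, it means among the compounds named here.

Measured compounds:
Compound 1 `Cc1nc2c(COc3ccccc3)cccn2c1C`: 48%
Compound 2 `CCSCc1c(C)nc2c(OCc3ccccc3)cccn12`: 36%

Of the compounds shown here, two have been tested in a functional assay on the whole organism with Rattus norvegicus as the target, with a stated time of 4 h, at a dose of 40 mg/kg by the intraperitoneal route (on this read-out higher numbers stand for more inhibition at the one dose given (going by the name of the read-out) and lower numbers for less inhibition), so far. Compound 1 gives 48%, while compound 2 gives 36%, the lower of the two numbers, a difference that lies beyond the usual scatter of the measurement. The next compound, compound 3 `Cc1nc2c(OCc3ccccc3)cccn2c1COC(=O)C(C)(C)C`, differs from compound 2 in a single place: ((tert-butyl)carbonyl)oxy in place of ethylsulfanyl on a saturated chain carbon bound to an aromatic carbon. Within the data shown here, no measured pair shows this kind of change, so nothing in the data says how large such a step should be. Among the measured compounds shown here, with only two numbers to go on, compound 3 is expected to land between the two measured values, so that the step of a number 6 percentage points higher from compound 2 to compound 3 (within the scatter) is estimated to stay within the scatter of this assay. The estimate for compound 3 in this assay is therefore 42%, with a range from 20% to 65%.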

Compound 3, a percentage reported as inhibition, in the whole organism at one dose (the size of the read-out at that dose, not a potency): 48%
The estimate for compound 3 lay 6 percentage points below the measured number; low and high end bracket the measured number.
By their numbers in this assay, from the lowest: compound 2; then compounds 1 and 3 (each within the scatter of the next).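

In this assay the exchange of ethylsulfanyl for ((tert-butyl)carbonyl)oxy gives a number 12 percentage points higher from compound 2 to compound 3 (beyond the scatter) and so shows that the group on this saturated chain carbon bound to an aromatic carbon can shift the read-out. The earlier compounds shown here offered no single-place comparison, so they could not show this, nor that the larger entering group, with 7 heavy atoms against 3, is accepted here without any loss of inhibition. No measurement on hand accounts for the step.

On these data alone, whether the gain comes from the sulfur leaving or the carbonyl entering stays open, as the two change together in this one pair. As far as these compounds go, how a hydroxyl, an amine or a longer alkylsulfanyl chain would read at this place also remains open.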